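The source may report more compounds than this note shows. Statements on the series, on what has been measured and on what is new or still open speak of the compounds shown alone.

Measured so far:
- compound 1 `Cc1ccc(CS/C(=C/c2cc(C)ccc2C)C(=O)c2ccc(Cl)cc2)cc1` — 10000 nM
- compound 2 `Cc1ccc(/C=C(/SCc2ccc(Cl)cc2)C(=O)c2ccc(Cl)cc2)s1` — 50000 nM
- compound 3 `Cc1ccc(CS/C(=C/c2ccc(C)s2)C(=O)c2ccc(Cl)cc2)cc1` — 50000 nM

All three were read in a functional assay on DU-145 cells (Homo sapiens) for inhibition, read by trypan blue exclusion, with a stated time of 96 h; a lower number here means a stronger inhibitor of growth, a higher number a weaker inhibitor of growth. Compound 2 and compound 3 share the highest numbers of the set, and the step of no change at the digits printed from compound 2 to compound 3 (within the scatter) lies within the scatter. The two cores differ by chloro in place of methyl on an aromatic carbon. Compound 1 is separated from compound 3 by 2,5-dimethylphenyl in place of 5-methylthiophen-2-yl on a double-bonded chain carbon bound to a double-bonded chain carbon, and that change gave a 5.0-fold lower number from compound 3 to compound 1 (0.70 log units; beyond the scatter), a modest step beyond the scatter.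

Compound 4 `Cc1ccc(C)c(/C=C(/SCc2ccc(Cl)cc2)C(=O)c2ccc(Cl)cc2)c1` is not yet measured. It stands to compound 2 as compound 1 stands to compound 3: the difference is 2,5-dimethylphenyl in place of 5-methylthiophen-2-yl on a double-bonded chain carbon bound to a double-bonded chain carbon, the same change, at the same place. For the measured compounds named here, the expected step in this assay is a 5.0-fold lower number from compound 2 to compound 4 (0.70 log units; beyond the scatter), resting on the single earlier instance a 5.0-fold lower number from compound 3 to compound 1 (0.70 log units; beyond the scatter) and on compound 2 giving 50000 nM. Compound 4 is therefore estimated at 10000 nM, expected to lie between 4000 nM and 30000 nM.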

Compound 4, concentration for 50% growth inhibition: 10000 nM
The estimate for compound 4 equals the measured number at the digits printed, and the stated range covers the measured number.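

In this assay, 2,5-dimethylphenyl in place of 5-methylthiophen-2-yl gives a 5.0-fold lower number from compound 2 to compound 4 (0.70 log units; beyond the scatter) on the chloro core, matching the step on the methyl core: the same change on two cores in this assay, a 5.0-fold lower number (0.70 log units; beyond the scatter) from compound 3 to compound 1 and a 5.0-fold lower number (0.70 log units; beyond the scatter) from compound 2 to compound 4, 1.0-fold (0.00 log units) apart, within the scatter of two such steps. Chloro in place of methyl on an aromatic carbon gives no change at the digits printed from compound 1 to compound 4 (within the scatter) with 2,5-dimethylphenyl present, and the same holds with 5-methylthiophen-2-yl present: the same change on two cores in this assay, no change at the digits printed (within the scatter) from compound 2 to compound 3 and no change at the digits printed (within the scatter) from compound 4 to compound 1, 1.0-fold (0.00 log units) apart, within the scatter of two such steps. This shows that each change carried over between the two cores shown, but with only one pair of steps per change, it does not show that either change would carry over to other cores.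

Open, going by these compounds, is how the series reads with an amine or a carboxylic acid in place of chloro or methyl on that aromatic carbon. Also open, on these data alone, is whether a longer chain on the sulfur keeps these steps.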